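A few compounds are considered here, and "the series" means these few. Any claim that something is new, unique, unknown or untested is made for them only; others in the source may bear on it.

Measured so far:
Compound 1 `Cc1cccnc1-c1ccccc1OCC1=NCCN1` — in a functional assay for activation of Alpha-1B adrenergic receptor (Homo sapiens), read by calcium flux (a higher number here means that more compound is needed for the effect, a lower number that less compound is needed), compound 1 gives < 100000 nM, which is a limit of the assay and not a number.
Compound 2 `Cc1ccnc(-c2ccccc2OCC2=NCCN2)c1` — in this assay compound 2 gives < 100000 nM, again a limit.
Compound 3 `c1cnc(-c2ccccc2OCC2=NCCN2)nc1` — in this assay compound 3 gives < 100000 nM, also a limit.

Going by the values given here, compound 3 therefore cannot be placed in any order among the compounds measured: its own value is a limit, and the two further values shown are limits as well, so no step between measured compounds can be sized. This is what the limit of < 100000 nM in this assay, at which 3 of the 3 values shown sit, records, and the set gives no foothold for a trend.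

The unmeasured compound 4 `c1csc(-c2ccccc2OCC2=NCCN2)c1` differs from compound 3 in one place: thiophen-2-yl in place of pyrimidin-2-yl on an aromatic carbon. Among the compounds with values here, no measured step shows how such a swap plays out here, so the step in this assay cannot be read from neighbours; a modest shift in either direction, or none beyond the scatter, is the honest expectation.

Compound 4 is expected to come in around 20000 nM, within the span from 2000 nM to 100000 nM, with a real chance that the assay once more reports only a limit. The expected step is a step that the limit leaves unreadable from compound 3 to compound 4.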

Compound 4, half-maximal effective concentration: 3.98 nM
Estimate against measurement, compound 4: 5000-fold (3.70 log units) above; measured number outside the range, below it.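

No step can be read from compound 3 to compound 4 in this assay, because the value of compound 3 is a limit and not a number: the limit of < 100000 nM in this assay, at which 3 of the 4 values shown sit.

The compounds shown leave open how large the change from pyrimidin-2-yl to thiophen-2-yl is, and whether any other group in that place would give a value like that of compound 4.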